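Expecting compound 4 after three level measurements

The source may hold more compounds than are shown below. What is called first, only, known or untested is meant among the compounds shown, and "the series" means these compounds.

Values measured so far in an ADME assay on HEK293 cells (Homo sapiens) for cytotoxicity; on this read-out lower numbers stand for stronger inhibition and higher numbers for weaker inhibition:
Compound 1 `CCCCCCCCCCCCCCNC(=O)[C@H](CO)/N=C/c1ccc(OC)cc1` gives 81700 nM
Compound 2 `CCCCCCCCCCCCCCNC(=O)[C@H](CO)/N=C/c1ccccc1O` gives 80800 nM
Compound 3 `CCCCCCCCCCCCCCNC(=O)[C@H](CO)/N=C/c1ccc(O)cc1` gives 71700 nM

Compound 3 stands level with the other two in this assay: a 1.1-fold lower number from compound 2 to compound 3 (0.05 log units; within the scatter) and a 1.1-fold lower number from compound 1 to compound 3 (0.06 log units; within the scatter) both lie within the scatter. The next compound, compound 4 `CCCCCCCCCCCCCCNC(=O)[C@H](CO)/N=C/c1ccc([N+](=O)[O-])cc1`, departs from compound 3 at one place: nitro in place of hydroxy on an aromatic carbon. In words, this is nitro in place of hydroxy on an aromatic carbon, para to a large group, or 4-hydroxyphenyl to 4-nitrophenyl.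

Going by the values given here, three measured steps bear on this change, though only indirectly, as none of them brings in nitro. The closest is a 1.1-fold lower number from compound 1 to compound 3 (0.06 log units; within the scatter), hydrogen in place of methyl on an oxygen on an aromatic ring. Next comes a 1.1-fold lower number from compound 2 to compound 3 (0.05 log units; within the scatter), 4-hydroxyphenyl in place of 2-hydroxyphenyl, and a 1.0-fold lower number from compound 1 to compound 2 (0.00 log units; within the scatter) completes the set. All three lie within the scatter, so no step beyond the scatter is expected in either direction, although the data do not show how nitro itself will read. The expected step is a 1.0-fold higher number from compound 3 to compound 4 (0.00 log units; within the scatter), an estimate only. Compound 4 is estimated at 72000 nM, with an expected range from 35000 nM to 130000 nM.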

Compound 4, half-maximal inhibitory concentration: 49500 nM
For compound 4 the middle estimate is 1.5-fold (0.16 log units) above the measured one, and the stated range covers the measured number.
By their numbers in this assay, from the lowest: compounds 4, 3, 2 and 1 (each within the scatter of the next).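

In this assay nitro in place of hydroxy on an aromatic carbon, para to a large group, gives a 1.4-fold lower number from compound 3 to compound 4 (0.16 log units; within the scatter) and thus takes away the hydrogen-bond donor of hydroxy without a step beyond the scatter. The other two comparisons give a 1.6-fold lower number from compound 2 to compound 4 (0.21 log units; within the scatter) and a 1.7-fold lower number from compound 1 to compound 4 (0.22 log units; within the scatter) and both also stay within the scatter, so the flat picture seen among the groups joined through oxygen now extends to a group joined through nitrogen. The data offer no measurement that would explain this flat read-out.

As far as these compounds go, whether any group at this place can move the number beyond the scatter remains open, and an amine or a carboxylic acid on the same aromatic carbon would be a direct test. All four compounds also share the same core, so they do not show how a shorter chain would read, or whether nitro would read the same as 2-nitrophenyl in place of 4-nitrophenyl.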